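A few compounds are considered here, and "the series" means these few. Any claim that something is new, unique, unknown or untested is made for them only; others in the source may bear on it.

Of the compounds shown here, three have so far been measured in an assay on isolated protein for binding affinity to adenosine receptor A1 (Bos taurus); on this read-out lower numbers stand for stronger inhibition and higher numbers for weaker inhibition. Compound 1 `CCCCCCNc1nc(-c2ccccc2)nc2c1nnn2Cc1ccccc1` gives 13200000 nM, compound 2 `CC(O)CNc1nc(-c2ccccc2)nc2c1nnn2Cc1ccccc1Cl` gives 32000000 nM, and compound 3 `CCCNc1nc(-c2ccccc2)nc2c1nnn2Cc1ccccc1` gives 37000000 nM. Compound 2 thus stands second highest of the three: its number lies within the scatter of compound 3 and is beyond the scatter only against compound 1. Within the data shown here, the single one-point step among the measured compounds, a 2.8-fold higher number from compound 1 to compound 3 (0.45 log units; beyond the scatter), shows that cutting hexyl back to propyl raises the number modestly.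

Compound 4 `CCCCCCNc1nc(-c2ccccc2)nc2c1nnn2Cc1ccccc1Cl` arises from compound 2 by pentyl in place of 1-hydroxyethyl on a saturated chain carbon bound to a nitrogen on an aromatic ring, so that the (2-hydroxypropyl)amino of compound 2 becomes the hexylamino that compound 1 carries. Among the measured compounds shown here, no measured pair isolates this exact change, because compounds 1 and 3 lack the chlorine present in compounds 2 and 4, but the step from compound 1 to compound 3 bears on it: hexyl gave the lower number there. A modest drop in the number is therefore expected, a 2.5-fold lower number from compound 2 to compound 4 (0.39 log units; beyond the scatter). Compound 4 is accordingly estimated at about 13000000 nM, with a range from 4500000 nM to 38000000 nM.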

Compound 4, inhibition constant: 31000000 nM
Beside the measured number, compound 4's estimate is 2.4-fold (0.38 log units) below it; low and high end bracket the measured number.
By their numbers in this assay, from the lowest: compound 1; then compounds 4, 2 and 3 (each within the scatter of the next).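

In this assay, pentyl in place of 1-hydroxyethyl on a saturated chain carbon bound to a nitrogen on an aromatic ring gives a 1.0-fold lower number from compound 2 to compound 4 (0.01 log units; within the scatter), so with the chlorine present, 2-hydroxypropyl and hexyl cannot be told apart. Chloro in place of hydrogen on an aromatic carbon gives a 2.3-fold higher number from compound 1 to compound 4 (0.37 log units; beyond the scatter), the first view of a change away from the amine chain, and it is a modest one seen in this single pair. No measurement on hand explains either result.

On these data alone, the change from 2-hydroxypropyl to hexyl alters the chain and removes the hydroxyl together, so the part played by each remains open. Also open, as far as these compounds go, is whether bromo or methoxy on that aromatic carbon, or an amine at the end of the chain, would shift the number.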